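Pyridinyl swap on the fused core of compound 1

The source may report more compounds than this note shows. Statements on the series, on what has been measured and on what is new or still open speak of the compounds shown alone.

Compound 1 `Cc1cn2c(/C=N/NC(=N)N)c(-c3cccnc3)nc2s1` gives 20900 nM in a functional assay on colon cells (Homo sapiens) for antiproliferative activity (a lower number here means a stronger inhibitor of growth, a higher number a weaker inhibitor of growth), the lowest number of the three shown. Compound 3 `N=C(N)N/N=C/c1c(-c2cccnc2)nc2sc(Cl)cn12` gives 21900 nM, and the step of a 1.0-fold higher number from compound 1 to compound 3 (0.02 log units; within the scatter) lies within the scatter. Compound 2 `N=C(N)N/N=C/c1c(-c2cc([N+](=O)[O-])c(Cl)cc2Cl)nc2sc(Cl)cn12` gives 50100 nM, a number beyond the scatter from compound 1. Compound 4 `Cc1cn2c(/C=N/NC(=N)N)c(-c3ccccn3)nc2s1` differs from compound 1 only in pyridin-2-yl in place of pyridin-3-yl on an aromatic carbon. Within the data shown here, no measured step touches the pyridinyl group; the sole step known, from compound 1 to compound 3, concerns chloro in place of methyl and stays within the scatter. With nothing bearing on this change, compound 4 is expected to give 21000 nM in this assay, within 8000 nM to 55000 nM. The estimated step of a 1.0-fold higher number from compound 1 to compound 4 (0.00 log units; within the scatter) is expected to remain within the scatter.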

Compound 4, concentration for total growth inhibition: 29500 nM
The estimate for compound 4 lay 1.4-fold (0.15 log units) below the measured number; the range from low to high includes it.
By their numbers in this assay, from the lowest: compounds 1, 3, 4 and 2 (each within the scatter of the next, the first and the last beyond it).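

This position on the core of compound 1 now has its first reading for a change of the pyridinyl group. In this assay pyridin-2-yl in place of pyridin-3-yl gives a 1.4-fold higher number from compound 1 to compound 4 (0.15 log units; within the scatter) and so stays within the scatter, which means this swap does not separate the two compounds. Nothing at hand accounts for this result.

Still open, from the compounds shown here alone, is whether pyridin-4-yl, or an amine or carboxylic acid carried on the pyridine ring, would move the number beyond the scatter. Also open, going by these compounds, is whether the pyridin-2-yl swap reads the same with chloro in place of methyl on the core.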